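From 4-methoxyphenyl to 3,4,5-trimethoxyphenyl on a shared core

A few compounds are considered here, and "the series" means these few. Any claim that something is new, unique, unknown or untested is made for them only; others in the source may bear on it.

Among the measured compounds shown here, in an ADME assay on Vero cells (Chlorocebus sabaeus) for cytotoxicity, read by MTT assay, with a stated time of 72 h (on this read-out lower numbers stand for higher toxicity in this test and higher numbers for lower toxicity in this test), compound 1 (`COc1ccc(-c2cc(-c3ccc(C4NC(=O)c5ccccc5N4)cc3)nc(N)n2)cc1`) gives 124000 nM and so holds the lower of the only two numbers available. Compound 2 (`CC1(c2ccc(Nc3nc(NCc4ccccc4)nc(NCc4ccccc4)n3)cc2)NC(=O)c2ccccc2N1`) gives 359000 nM in the same test, and that gap lies beyond the usual scatter. Compound 3 (`COc1ccc(CNc2nc(NCc3ccc(OC)cc3)nc(Nc3ccc(C4(C)NC(=O)c5ccccc5N4)cc3)n2)cc1`) adds no number to the comparison, its entry reading "not determined" (no result reported) and nothing more.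

Compound 4 (`COc1cc(-c2cc(-c3ccc(C4NC(=O)c5ccccc5N4)cc3)nc(N)n2)cc(OC)c1OC`) keeps the core of compound 1 and changes one group, with 3,4,5-trimethoxyphenyl in place of 4-methoxyphenyl on an aromatic carbon. For the measured compounds named here, no pair of measured compounds here differs in only one place, so the data do not show the size of such a change directly. The expectation therefore stays anchored on compound 1 at 124000 nM and allows only a slight move toward a lower number, with no step beyond the scatter. The expected change is a 1.2-fold lower number from compound 1 to compound 4 (0.09 log units; within the scatter) and would remain within that scatter. In this assay the estimated value for compound 4 is 100000 nM with an expected range from 35000 nM to 260000 nM around that middle.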

Compound 4, half-maximal cytotoxic concentration: 85900 nM
Beside the measured number, compound 4's estimate is 1.2-fold (0.07 log units) above it; measured number inside the range.
By their numbers in this assay, from the lowest: compounds 4 and 1 (each within the scatter of the next); then compound 2.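

Placing 3,4,5-trimethoxyphenyl in place of 4-methoxyphenyl on an aromatic carbon of the shared core gives the first direct reading of a single change in this assay, a 1.4-fold lower number from compound 1 to compound 4 (0.16 log units; within the scatter). At this position, opposite the ring nitrogen, a group of 12 heavy atoms with 3 hydrogen-bond acceptors therefore stands where one of 8 heavy atoms with 1 hydrogen-bond acceptor stood, and the two compounds cannot be told apart in this test. Nothing measured here speaks to why the read-out responds in this way.

The compounds shown leave open whether a group of another kind on this aromatic carbon, such as an amine, a carboxylic acid or a longer chain in place of the substituted phenyl, would give a step beyond the scatter. They also leave open how the read-out would respond if the amino group on the shared core gave way to a methylamino or an acetamido group, since all the changes seen on this core so far are confined to the single phenyl substituent.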